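A few compounds are considered here, and "the series" means these few. Any claim that something is new, unique, unknown or untested is made for them only; others in the source may bear on it.

Going by the values given here, the three compounds measured so far share one core and differ in the linker and in the group on the carbonyl carbon of the ring amide. Compound 1 `CCn1c(-c2cnc(C)nc2)nc2c(O[C@H]3CCN(C(=O)C4CC4)C3)ncnc21` carries a cyclopropylcarbonyl, and in an ADME assay on the whole organism (Rattus norvegicus, strain Wistar Han) for pharmacokinetics (a lower number here means slower removal, a higher number faster removal of the compound), compound 1 gives 9.7 mL/min/kg. Compound 2 `CCn1c(-c2ccc(C(F)(F)F)nc2)nc2c(O[C@H]3CCN(C(=O)N4CC(OC)C4)C3)ncnc21` gives 1.7 mL/min/kg in this assay. Compound 3 `CCn1c(-c2cnc(C)nc2)nc2c(N[C@H]3CCN(C(=O)[C@H]4C[C@@H](OC)C4)C3)ncnc21` gives 6.9 mL/min/kg. Among these three numbers compound 3 stands second highest: its value lies within the scatter of compound 1, while compound 2 sits clearly lower, beyond the scatter.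

Among the compounds with values here, compound 4 `CCn1c(-c2cnc(C)nc2)nc2c(N[C@H]3CCN(C(=O)C4CC4)C3)ncnc21` is the next step from compound 3. cyclopropyl in place of 3-methoxycyclobutyl on a carbonyl carbon No pair of measured compounds isolates this change, so the expectation rests on the three values themselves. Compound 1 carries the same cyclopropylcarbonyl as compound 4 and differs from compound 3 in two places rather than one. In this assay compound 1 gives 9.7 mL/min/kg. That number lies within the scatter of compound 3. The step of a 1.3-fold higher number from compound 3 to compound 4 (0.12 log units; within the scatter) is therefore expected to be small, at most a modest shift toward faster removal, and not beyond the scatter. Compound 4 is estimated at 9 mL/min/kg, with a range from 4.5 mL/min/kg to 18 mL/min/kg.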

Compound 4, clearance: 8.1 mL/min/kg
Compound 4: middle estimate off by 1.1-fold (0.05 log units), on the high side, within the range that was stated.
By their numbers in this assay, from the lowest: compound 2; then compounds 3, 4 and 1 (each within the scatter of the next).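

Swapping the (3-methoxycyclobutyl)carbonyl for a cyclopropylcarbonyl gives, in this assay, a 1.2-fold higher number from compound 3 to compound 4 (0.07 log units; within the scatter), the first reading of a single change at this position, and it lies within the scatter. The comparison therefore shows that, with the rest of the structure held constant, this assay does not separate 3-methoxycyclobutyl, with its oxygen and 2 defined stereocentres, from the smaller cyclopropyl on a carbonyl carbon bonded to an amide-type nitrogen in a ring. No supporting measurement is available to explain why the two compounds read so closely.

This single pair leaves open whether the same holds for groups of a different kind at this carbonyl carbon, such as a primary amine, a carboxylic acid or a longer alkyl chain, any of which might or might not give a step beyond the scatter. It also leaves unassigned the lower number of compound 2, which differs from the other compounds in more than one place, so that no single part of its structure can be tied to its value of 1.7 mL/min/kg.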